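Piperazine amides with a cyclopropyl ketone tail at the histamine H2 receptor

The compounds below may be only part of what the source reports. "The series", "measured", "known", "first", "only" and "open" are said of these compounds alone.

Three compounds share one core, a cyclopropyl ketone joined through a propyl ether to a piperazine, and differ only in the group on the amide carbonyl. Compound 1 `O=C(c1ccc(OCCCN2CCN(C(=O)[C@H]3CCCN3)CC2)cc1)C1CC1` gives 53700 nM in an assay for binding affinity to histamine H2 receptor (Homo sapiens); a lower number here means a stronger inhibitor, a higher number a weaker inhibitor. Compound 2 `CC(C)(C)[C@@H](N)C(=O)N1CCN(CCCOc2ccc(C(=O)C3CC3)cc2)CC1` gives 19100 nM, and compound 3 `CNCC(=O)N1CCN(CCCOc2ccc(C(=O)C3CC3)cc2)CC1` gives 79400 nM. Compound 3 carries the highest of the three numbers, but its gap to compound 1 is within the scatter, so it cannot be set apart from compound 1; only compound 2 stands clearly lower, since a 4.2-fold higher number from compound 2 to compound 3 (0.62 log units; beyond the scatter).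

Compound 4 `CC(C)N[C@H](C)C(=O)N1CCN(CCCOc2ccc(C(=O)C3CC3)cc2)CC1` is the next step: 1-(isopropylamino)ethyl in place of (methylamino)methyl on a carbonyl carbon. Going by the values given here, the steps that bear on it both point the same way. Moving from pyrrolidin-2-yl to 1-amino-2,2-dimethylpropyl gave a 2.8-fold lower number from compound 1 to compound 2 (0.45 log units; beyond the scatter), and the reverse move from compound 2 to compound 3, replacing a branched group with (methylamino)methyl, gave a 4.2-fold higher number from compound 2 to compound 3 (0.62 log units; beyond the scatter). A branched group with a defined stereocentre returning in compound 4 is therefore expected to lower the number by a modest step, a 2.6-fold lower number from compound 3 to compound 4 (0.42 log units; beyond the scatter). Compound 4 is estimated at 30000 nM, within a range from 12000 nM to 80000 nM.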

Compound 4, inhibition constant: 50100 nM
Compound 4: the middle estimate sits 1.7-fold (0.22 log units) below what was measured; measured number inside the range.
By their numbers in this assay, from the lowest: compound 2; then compounds 4, 1 and 3 (each within the scatter of the next).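

Going from (methylamino)methyl to 1-(isopropylamino)ethyl on the carbonyl carbon adds carbon atoms and a defined stereocentre, yet this larger group cannot be told apart from the smaller one in this assay (a 1.6-fold lower number from compound 3 to compound 4 (0.20 log units; within the scatter)), nor from pyrrolidin-2-yl (a 1.1-fold lower number from compound 1 to compound 4 (0.03 log units; within the scatter)). Among the four compounds, 1-amino-2,2-dimethylpropyl is therefore still the only group that stands apart, and a branched group with a defined stereocentre does not by itself match it (a 2.6-fold higher number from compound 2 to compound 4 (0.42 log units; beyond the scatter)). No measurement shown here explains this difference.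

In 1-amino-2,2-dimethylpropyl, the tert-butyl part and the unsubstituted amine come together, so the compounds shown cannot say which of them matters. Open too, on these data alone, is how 1-aminoethyl, with the amine but no tert-butyl part, or 1-(methylamino)-2,2-dimethylpropyl would read in this assay.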